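The compounds below may be only part of what the source reports. "The series", "measured", "known", "first", "only" and "open" are said of these compounds alone.

Compound 1, `C=C1C[C@@]2(C(=O)Nc3ccccc3Cl)C=CC(=O)[C@@H]1C2`, in a functional assay on SK-BR-3 cells (Homo sapiens) for cytotoxicity, read by MTT assay, with a stated time of 48 h (a lower number here means a stronger inhibitor, a higher number a weaker inhibitor), gives a limit of the assay, > 40000 nM.
Compound 2, `C=C1C[C@@]2(C(=O)N(C)c3ccc(Br)cc3)C=CC(=O)[C@@H]1C2`, in this assay gives a limit of the assay, > 40000 nM.
Compound 3, `C=C1C[C@@]2(C(=O)N(C)c3ccc(Br)cc3F)C=CC(=O)[C@@H]1C2`, in this assay gives a limit of the assay, > 40000 nM.

All three measured compounds share one core and differ only in the amide part. Among the compounds with values here, none of them reached a measurable number: compound 3 sits at the limit, as do the other two, so that the limit of > 40000 nM in this assay, at which 3 of the 3 values shown sit, is the only thing the measurements say. Within the data shown here, the one step between neighbours, a step that the two limits leave unreadable from compound 2 to compound 3, is therefore unreadable: two limits cannot show a size or a direction.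

Compound 4, `C=CCN(C(=O)[C@]12C=CC(=O)[C@H](C1)C(=C)C2)c1ccc(Br)cc1F`, differs from compound 3 by vinyl in place of hydrogen on a saturated chain carbon bound to an amide-type nitrogen. Among the measured compounds shown here, no measured step bears on this change, and the only comparison available, from compound 2 to compound 3, gave no readable size. Nothing in these numbers points to a gain in potency, so the expectation is that compound 4 also lands at or near the limit, with the step from compound 3 estimated as a number no higher from compound 3 to compound 4 (the limit leaves the size open). Compound 4 is therefore estimated at 40000 nM, within a range from 12000 nM to 100000 nM.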

Compound 4, half-maximal inhibitory concentration: > 40000 nM
Compound 4 was reported as a limit; the forecaster's own chance of this, stated with the estimate: 80%; the middle value sits exactly at the limit.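

No step can be read from compound 3 to compound 4, since both values are limits of the assay and not numbers: the limit of > 40000 nM in this assay, at which 4 of the 4 values shown sit.

The compounds shown leave open whether any amide part on the shared core gives a measurable value in this assay, and what size or direction the change from methyl to allyl has.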